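Dichlorophenyl replacing chlorophenyl in compound 3

The source may hold more compounds than are shown below. What is called first, only, known or untested is meant among the compounds shown, and "the series" means these compounds.

Three compounds share the aryl ether core. Compound 1 `Fc1cc(Nc2cc(Nc3ccc(Cl)cc3)ncn2)ccc1Oc1ccncc1-c1cccnc1` gives 240 nM in a functional assay on MKN-45 cells (Homo sapiens) for cytotoxicity, read by MTT assay, with a stated time of 72 h; on this read-out higher numbers stand for weaker inhibition and lower numbers for stronger inhibition. For the measured compounds named here, compound 2 `COc1cc(Nc2cc(Nc3ccc(Oc4ccncc4-c4cccnc4)c(F)c3)ncn2)cc(OC)c1` gives 1750 nM; the only single-point step so far is a 7.3-fold higher number from compound 1 to compound 2 (0.86 log units; beyond the scatter). Compound 3 `Cn1c(=O)c(C(=O)Nc2ccc(Oc3ccncc3-c3cccnc3)c(F)c2)nn(-c2ccc(Cl)cc2)c1=O` gives 1600 nM, the second highest of the three numbers, within the scatter of compound 2 and well beyond the scatter from compound 1. Compound 4 `Cn1c(=O)c(C(=O)Nc2ccc(Oc3ccncc3-c3cccnc3)c(F)c2)nn(-c2c(Cl)cccc2Cl)c1=O` differs from compound 3 by 2,6-dichlorophenyl in place of 4-chlorophenyl on an aromatic nitrogen. Going by the values given here, no measured step touches this position; the one known step changes an aryl on a nitrogen of a different core and is modest. Nothing argues for a shift beyond the scatter, so compound 4 is expected to give 1800 nM (range 600 nM to 5400 nM), an estimated step of a 1.1-fold higher number from compound 3 to compound 4 (0.05 log units; within the scatter).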

Compound 4, half-maximal inhibitory concentration: 3930 nM
Compound 4: the middle estimate sits 2.2-fold (0.34 log units) below what was measured; the measured number falls inside the stated range.
By their numbers in this assay, from the lowest: compound 1; then compounds 3 and 2 (each within the scatter of the next); then compound 4.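

In this assay, the aryl group on the aromatic nitrogen proves sensitive to substitution: 2,6-dichlorophenyl in place of 4-chlorophenyl gives a 2.5-fold higher number from compound 3 to compound 4 (0.39 log units; beyond the scatter), a modest loss of inhibition that lies beyond the scatter. For the compounds shown here, this is the only measured step at this position, so it fixes the direction for this one change alone. No available data bear on the reason for the shift.

Still open, going by these compounds, is where 2-chlorophenyl or unsubstituted phenyl would fall at this nitrogen. Also open, on these data alone, is whether 2,6-dichlorophenyl would have the same effect on the core of compound 1.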